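Swapping a tert-butylbenzyl for a dichlorobenzyl amine

The compounds below may be only part of what the source reports. "The series", "measured", "known", "first", "only" and "open" are said of these compounds alone.

Of the compounds shown here, three built on a shared core have been measured in a functional assay on HPAC cells (Homo sapiens) for inhibition, read by MTT assay, with a stated time of 72 h; a higher number here means a weaker inhibitor of growth, a lower number a stronger inhibitor of growth. Compound 1 `O=S(=O)(NCCNCc1cccc2ccccc12)c1cc(C(F)(F)F)cc(C(F)(F)F)c1` gives 18000 nM, compound 2 `CC(C)(C)c1ccc(CNCCCNS(=O)(=O)c2cc(C(F)(F)F)cc(C(F)(F)F)c2)cc1` gives 2300 nM, and compound 3 `O=S(=O)(NCCNCc1ccc(-c2ccccc2)cc1)c1cc(C(F)(F)F)cc(C(F)(F)F)c1` gives 2800 nM. Compound 2 has the lowest number of the three: the gap to compound 3 is within the usual scatter of repeated measurements, so the two cannot be ranked against each other, while the gap to compound 1 lies well beyond the scatter.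

Compound 4 `O=S(=O)(NCCCNCc1ccc(Cl)c(Cl)c1)c1cc(C(F)(F)F)cc(C(F)(F)F)c1` has not yet been tested. Going by the values given here, its one difference from compound 2 is 3,4-dichlorophenyl in place of 4-(tert-butyl)phenyl on a saturated chain carbon bound to an amine nitrogen; cut one bond further out, the change reads 4-(tert-butyl)benzyl to 3,4-dichlorobenzyl. The amine chain and the core are unchanged.

Among the compounds with values here, no pair among the measured compounds shows this exact change, so there is no direct step to borrow from. The values of compounds 2 and 3 show that two different aryl groups on this chain can give numbers close together, whereas compound 1 shows that another aryl group can sit far higher. On that basis a small rise in the number, no larger than the scatter, is the expectation for the step of a 1.7-fold higher number from compound 2 to compound 4 (0.24 log units; within the scatter). Compound 4 is estimated to give about 4000 nM in this assay, with a likely range from 1500 nM to 12000 nM.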

Compound 4, concentration for 50% growth inhibition: 2500 nM
The estimate for compound 4 lay 1.6-fold (0.20 log units) above the measured number; the range from low to high includes it.
By their numbers in this assay, from the lowest: compounds 2, 4 and 3 (each within the scatter of the next); then compound 1.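

In this assay, placing 3,4-dichlorophenyl where 4-(tert-butyl)phenyl stood, on a saturated chain carbon bound to an amine nitrogen, gives a 1.1-fold higher number from compound 2 to compound 4 (0.04 log units; within the scatter), so the two compounds cannot be ranked against each other. Going by these compounds alone, this is the first pair in the set that differs in one place only, and it shows directly that, on this chain and shared core, a group of 10 carbon heavy atoms and a group of 8 heavy atoms that include 2 chlorine atoms can replace one another with no readable difference in growth inhibition. No supporting measurement is available to explain why the two groups match.

As far as these compounds go, whether this position would tolerate a very different substituent remains open, for example a benzyl group carrying a carboxylic acid or a plain benzyl group with no substituent on its ring. This single pair also leaves open whether the same exchange would read the same way on a longer chain, or in cell lines other than the one tested here.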